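A few compounds are considered here, and "the series" means these few. Any claim that something is new, unique, unknown or untested is made for them only; others in the source may bear on it.

In a functional assay on MDA-MB-231 cells (Homo sapiens) for antiproliferative activity, read by MTT assay, with a stated time of 24 h (on this read-out lower numbers stand for stronger inhibition and higher numbers for weaker inhibition), compound 1 `Cc1cccc(NNC(=O)c2cccc(NS(=O)(=O)c3cnc(O)nc3O)c2)c1` gives > 20000 nM, a limit of the assay and not a number. Compound 2 `Cc1cccc(NNC(=O)c2ccccc2NS(=O)(=O)c2cnc(O)nc2O)c1` gives > 20000 nM, which is likewise a limit. For the measured compounds named here, compound 3 `O=C(NNc1ccccc1Cl)c1ccccc1NS(=O)(=O)c1cnc(O)nc1O` gives 18900 nM, the only actual number in the set. The other two results stand at the limit of > 20000 nM in this assay, at which 2 of the 3 values shown sit, so the data offer little room for comparison.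

Compound 4 `O=C(NNc1ccccc1F)c1ccccc1NS(=O)(=O)c1cnc(O)nc1O` differs from compound 3 at a single place: fluoro in place of chloro on an aromatic carbon. This puts fluoro in place of chloro on an aromatic carbon, ortho to a large group, turning the 2-chlorophenyl into a 2-fluorophenyl. Going by the values given here, no measured step makes this exact exchange. The nearest is an at least 1.0-fold lower number from compound 2 to compound 3 (0.02 log units; that floor lies within the scatter), where 2-chlorophenyl replaces 3-methylphenyl on an amine nitrogen, and that step lies within the scatter and rests on a limit. It therefore gives no reason to expect a real shift in either direction, and the expectation stays anchored on compound 3 at 18900 nM. The expected change is a 1.1-fold higher number from compound 3 to compound 4 (0.02 log units; within the scatter), which means no step beyond the scatter. A result reported only as a limit would be no surprise. For compound 4 the estimate is 20000 nM, with an expected range from 11000 nM to 40000 nM.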

Compound 4, half-maximal inhibitory concentration: > 20000 nM
Compound 4: only a limit was reported; the forecaster's own chance of this, stated with the estimate: 50%; the middle value lies on the limit itself.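

In this assay, for the compounds shown here, the exchange of chloro for fluoro on an aromatic carbon, ortho to a large group, gives an at least 1.0-fold higher number from compound 3 to compound 4 (0.02 log units; that floor lies within the scatter), the first step in which only the halogen at this place changes. Compound 4 gives > 20000 nM, which is a limit of the assay and not a number, so this step has only a floor and sets no real size for the exchange. The step between compound 2 and compound 4 cannot be read, and the set now rests even more on one limit: the limit of > 20000 nM in this assay, at which 3 of the 4 values shown sit.

The compounds shown leave open whether another group on this aromatic carbon, such as a methoxy group, a trifluoromethyl group or a carboxylic acid, would give a number clearly clear of that limit. They also leave open how the exchange of chloro for fluoro would read on a compound whose values on both sides are actual numbers.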